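Thiophen-2-yl to 1-methyl-1H-pyrrol-2-yl: working notes

The source may hold more compounds than are shown below. What is called first, only, known or untested is meant among the compounds shown, and "the series" means these compounds.

Compound 1 `Oc1ccc(CN(Cc2ccccc2)Cc2ccc(O)c3ncccc23)c2cccnc12`: < 0.5 uM (a limit)
Compound 2 `Oc1ccc(CN(Cc2cccs2)Cc2ccc(O)c3ncccc23)c2cccnc12`: < 0.2 uM (a limit)

Compound 2 reads < 0.2 uM in a functional assay on U-87MG ATCC cells (Homo sapiens) for antiproliferative activity, with a stated time of 3 days (a lower number here means that less compound is needed, a higher number that more compound is needed for the effect), and this is a limit, not a number. Compound 1 reads < 0.5 uM in this assay, and this too is a limit. Neither compound therefore gives an exact starting point.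

Compound 3 `Cn1cccc1CN(Cc1ccc(O)c2ncccc12)Cc1ccc(O)c2ncccc12` keeps the shared core of compound 2 and changes one group: 1-methyl-1H-pyrrol-2-yl in place of thiophen-2-yl on a saturated chain carbon bound to an amine nitrogen. The new group, 1-methyl-1H-pyrrol-2-yl, is again a five-membered aromatic ring with 1 hetero atom.

Within the data shown here, one measured step bears on this place: a step that the two limits leave unreadable from compound 1 to compound 2. Its size cannot be read, so it offers no measure of how much this assay responds to a change of this group. No step beyond the scatter is therefore expected, and no direction is favoured. The estimated step is a step that the limit leaves unreadable from compound 2 to compound 3.

Compound 3 is estimated at 0.15 uM, with an expected range from 0.05 uM to 0.45 uM.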

Compound 3, concentration for half-maximal effect: 2 uM
Compound 3: the middle estimate sits 13-fold (1.12 log units) below what was measured; measured number outside the range, above it.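

In this assay the place on a saturated chain carbon bound to an amine nitrogen now gives a readable response to a change of group, with an at least 10-fold higher number from compound 2 to compound 3 (1.00 log units; beyond the scatter) and an at least 4.0-fold higher number from compound 1 to compound 3 (0.60 log units; beyond the scatter), while the step from compound 1 to compound 2 cannot be read. Thiophen-2-yl and 1-methyl-1H-pyrrol-2-yl are each one five-membered aromatic ring with 1 hetero atom and have the same counts of hydrogen-bond donors and acceptors, so these shared features alone do not keep the number low at this place. Both readable steps give only a minimum size, and the step from compound 2 starts from a limit, not a number: the limit of < 0.2 uM in this assay, at which 1 of the 3 values shown sits.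

The change brings in nitrogen for sulfur and adds the methyl of 1-methyl-1H-pyrrol-2-yl in a single step, so the compounds shown do not separate the two; 1H-pyrrol-2-yl without the methyl, or furan-2-yl, would bear on this. No measured property in the compounds shown accounts for the step, and the true distance between compound 1 and compound 2 remains unknown.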